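The source may report more compounds than this note shows. Statements on the series, on what has been measured and on what is new or still open speak of the compounds shown alone.

In an ADME assay on Vero cells (Chlorocebus sabaeus) for cytotoxicity, read by MTT assay (a lower number here means a stronger inhibitor, a higher number a weaker inhibitor), compound 1 (`CN(Cc1cccnc1)c1cc(C(=O)Nc2ccccc2)ncn1`) gives "not determined" (no result reported) as its result, so it offers no number for comparison. Compound 2 (`CN(Cc1ccc(C(F)(F)F)nc1)c1cc(C(=O)Nc2ccccc2)ncn1`) gives 258000 nM and compound 3 (`COc1ccc(NC(=O)c2ccnc(N(C)Cc3ccc(F)cc3)n2)cc1`) gives 273000 nM in the same test. These two values lie within the usual scatter of each other, so compound 2 stands with compound 3 and neither can be ranked. Compound 4 (`CN1CCN(c2ccc(NC(=O)c3cc(N(C)Cc4ccc(C(F)(F)F)nc4)ncn3)cc2)CC1`) differs from compound 2 in one place, with 4-methylpiperazin-1-yl in place of hydrogen on an aromatic carbon. For the measured compounds named here, no measured pair shows the effect of such a change, so any expectation is loose. A moderate fall in the number, beyond the scatter, is expected (estimated step: a 3.2-fold lower number from compound 2 to compound 4 (0.51 log units; beyond the scatter)). The estimate for compound 4 is 80000 nM (expected range 20000 nM to 280000 nM).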

Compound 4, half-maximal inhibitory concentration: 45200 nM
Compound 4: the middle estimate sits 1.8-fold (0.25 log units) above what was measured, and the stated range covers the measured number.
By their numbers in this assay, from the lowest: compound 4; then compounds 2 and 3 (each within the scatter of the next).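

In this assay, putting 4-methylpiperazin-1-yl in place of hydrogen on the carbon-only aromatic ring gives a 5.7-fold lower number from compound 2 to compound 4 (0.76 log units; beyond the scatter) and so shows that the number responds to a change at this position. No other pair shown tests this position. Nothing available explains the step. As far as these compounds go, whether the methyl group or the whole ring matters remains open, as a plain piperazine or a morpholine at this position would be needed to tell. A single pair also leaves open whether the step would recur on other cores.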